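Adding a Third Methoxy Group to a Dimethoxy Stilbene-Like Lactam

The compounds below may be only part of what the source reports. "The series", "measured", "known", "first", "only" and "open" are said of these compounds alone.

Measured so far:
compound 1, `O=c1ccoc(/C=C/c2ccccc2)c1`, 509 uM
compound 2, `COc1ccc(/C=C/c2cc(=O)cco2)cc1`, 606 uM
compound 3, `COc1cc(/C=C/C2CC=CC(=O)N2)cc(OC)c1`, 146 uM

These three compounds were tested in a functional assay on NCI-H460 cells (Homo sapiens) for inhibition, read by sulforhodamine B assay, with a stated time of 48 h; a lower number here means a stronger inhibitor of growth, a higher number a weaker inhibitor of growth. Compound 1 and compound 2 share one core, while compound 3 has another; the difference between the two cores is not broken down here. Compound 3 stands lowest of the three numbers, beyond the scatter from both others.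

Compound 1 and compound 2 differ by one change, (methoxy in place of hydrogen on an aromatic carbon), which gave a 1.2-fold higher number from compound 1 to compound 2 (0.08 log units; within the scatter).

Compound 4, `COc1cc(/C=C/C2CC=CC(=O)N2)cc(OC)c1OC`, has not yet been measured. It differs from compound 3 by methoxy in place of hydrogen on an aromatic carbon. Among the measured compounds shown here, this is the same kind of change as the one from compound 1 to compound 2, but the surroundings differ: in compound 4 the new methoxy sits ortho to two methoxy groups (2 heavy atoms each), whereas in compound 2 it sits only para to a group of 9 heavy atoms.

Because the earlier change gave a 1.2-fold higher number from compound 1 to compound 2 (0.08 log units; within the scatter), a similarly small step is expected here, a 1.2-fold higher number from compound 3 to compound 4 (0.07 log units; within the scatter). Compound 4 is therefore estimated at 170 uM in this assay, likely between 80 uM and 350 uM.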

Compound 4, concentration for growth inhibition (reported as GI): > 864 uM
Compound 4: no number, only a limit (the forecaster's own chance of this, stated with the estimate: 5%); middle value at least 5.0-fold (0.70 log units) from the limit.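

In this assay, methoxy in place of hydrogen on an aromatic carbon gave an at least 5.9-fold higher number from compound 3 to compound 4 (0.77 log units; beyond the scatter), so the small step seen on the core of compound 1 did not carry over to the core of compound 3: the same change on two cores in this assay, a 1.2-fold higher number (0.08 log units; within the scatter) from compound 1 to compound 2 and an at least 5.9-fold higher number (0.77 log units; beyond the scatter) from compound 3 to compound 4, at least 4.9-fold (0.69 log units) apart, beyond the scatter of two such steps

Compound 4 gives only a limit, > 864 uM, and not a number, so the full size of this step cannot be read: the limit of > 864 uM in this assay, at which 1 of the 4 values shown sits.

The comparison shows that the same change need not give the same result in this series, but it does not show whether the different core or the different surroundings of the new methoxy, which in compound 4 sits ortho to two methoxy groups, accounts for the gap.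

The compounds shown leave open how a lone methoxy on the core of compound 3 would behave, and how a trimethoxy pattern would behave on the core of compound 1. They also leave open whether a hydroxy group, a chlorine atom or a longer ethoxy chain in the same place would give a similar result.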